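Fluoro to methyl at the assay limit

The source may report more compounds than this note shows. Statements on the series, on what has been measured and on what is new or still open speak of the compounds shown alone.

- compound 1 `Nn1c(SCc2ccccc2[N+](=O)[O-])nnc1-c1c[nH]c2ccccc12`: > 100000 nM (a limit)
- compound 2 `Nn1c(SCc2cccc([N+](=O)[O-])c2)nnc1-c1c[nH]c2ccccc12`: > 100000 nM (a limit)
- compound 3 `Nn1c(SCc2ccc(F)cc2)nnc1-c1c[nH]c2ccccc12`: > 100000 nM (a limit)

All readings so far come from a functional assay on Jurkat cells (Homo sapiens) for cytotoxicity, with a stated time of 24 h; a higher number here means a weaker inhibitor, a lower number a stronger inhibitor. In this assay compound 3 gives > 100000 nM, which is a limit and not a number. The other two compounds stand in the same place, and the series shows (the limit of > 100000 nM in this assay, at which 3 of the 3 values shown sit). For the measured compounds named here, no compound can therefore be ranked against another, and no measured step is available.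

Compound 4 `Cc1ccc(CSc2nnc(-c3c[nH]c4ccccc34)n2N)cc1` has methyl in place of fluoro on an aromatic carbon, para to a large group, and otherwise matches compound 3 (methyl in place of fluoro on an aromatic carbon). No step beyond the scatter is expected in this assay because the limit of > 100000 nM in this assay, at which 3 of the 3 values shown sit, holds for every measured compound. The expected change is a number no higher from compound 3 to compound 4 (the limit leaves the size open). A reading that is again only a limit is the likeliest outcome. Compound 4 is estimated at 100000 nM, with an expected range of 30000 nM to 200000 nM.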

Compound 4, half-maximal inhibitory concentration: > 100000 nM
Compound 4 ended at the assay's limit; the forecaster's own chance of this, stated with the estimate: 75%; the middle value lies on the limit itself.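

For the compounds shown here, no step from compound 3 to compound 4 can be read, since both compounds give a limit and not a number: the limit of > 100000 nM in this assay, at which 4 of the 4 values shown sit. The compounds shown leave open whether any change to the substituted benzyl group or the shared core would give a reading below that limit.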